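Amide substituent change on the shared core: piperidinyl to fluoroanilide

The source may report more compounds than this note shows. Statements on the series, on what has been measured and on what is new or still open speak of the compounds shown alone.

Going by the values given here, compound 2, `COc1cc2nccc(Oc3ccc(Nc4nn(C)cc4C(=O)N4CCCCC4)cc3)c2cc1C(N)=O`, is the only compound of the pair to give a number in a functional assay on BaF3 cells (Mus musculus) for antiproliferative activity, read by CCK-8 assay and cell counting, with a stated time of 76 h; a lower number here means a stronger inhibitor, a higher number a weaker inhibitor: compound 2 gives 5650 nM. Compound 1, `COc1cc2nccc(Oc3ccc(Nc4nn(C)cc4C(=O)NC45CCC(CC4)CC5)cc3)c2cc1C(N)=O`, sits at a limit of this assay, > 10000 nM, which is a limit rather than a number, as noted in the limit of > 10000 nM in this assay, at which 1 of the 2 values shown sits. Among the compounds with values here, the one measured step, an at least 1.7-fold lower number from compound 1 to compound 2 (0.24 log units; that floor lies within the scatter), swaps the group on the carbonyl carbon and gives only a floor that stays within the scatter, so it shows little about how much the amide substituent matters.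

Compound 3, `COc1cc2nccc(Oc3ccc(Nc4nn(C)cc4C(=O)Nc4ccc(F)cc4)cc3)c2cc1C(N)=O`, carries the next change at the same place: (4-fluorophenyl)amino in place of piperidin-1-yl on a carbonyl carbon. Within the data shown here, no measured step covers the exchange of a non-aromatic amine for an aromatic amino group at this carbonyl, so the prior rests on compound 2 alone; the step from compound 1 to compound 2 shows at most that variation here moves the number downward without reaching beyond the scatter. The expectation for compound 3 is a modest improvement, a 2.8-fold lower number from compound 2 to compound 3 (0.45 log units; beyond the scatter), with wide uncertainty. Compound 3 is estimated at 2000 nM, within 300 nM to 10000 nM.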

Compound 3, half-maximal inhibitory concentration: 3060 nM
Compound 3: the middle estimate sits 1.5-fold (0.18 log units) below what was measured, and the stated range covers the measured number.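

In this assay, putting (4-fluorophenyl)amino in place of piperidin-1-yl on the carbonyl carbon gives a 1.8-fold lower number from compound 2 to compound 3 (0.27 log units; within the scatter), so the aromatic amino group and the non-aromatic ring cannot be told apart here, even though the change adds an aromatic ring and a hydrogen-bond donor. Going by these compounds alone, the exchange on the amide-type nitrogen, a 4-fluorophenyl ring in place of the group with two non-aromatic carbon rings, gives an at least 3.2-fold lower number from compound 1 to compound 3 (0.51 log units; beyond the scatter), the first step at this position to lie beyond the scatter. That step is a floor rather than a measured size, since compound 1 stands at a limit and not at a number: the limit of > 10000 nM in this assay, at which 1 of the 3 values shown sits.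

Open, on these data alone, is whether the fluorine contributes anything, which a plain phenyl or a 4-chlorophenyl ring at the same place would test, and whether the amide hydrogen matters, which a methyl group on that nitrogen would test. Also open, as far as these compounds go, is how a morpholine or piperazine ring on the same carbonyl carbon would read against piperidin-1-yl.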